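Swapping the triazole aryl group for a chlorobenzimidazolylmethyl arm

A few compounds are considered here, and "the series" means these few. Any claim that something is new, unique, unknown or untested is made for them only; others in the source may bear on it.

Measured so far:
compound 1 `CN(CCNCc1cn(-c2ccc(F)cc2)nn1)CCNc1ccnc2cc(Cl)ccc12` gives 12000 nM
compound 2 `CN(CCNCc1cn(-c2cccc(Cl)c2)nn1)CCNc1ccnc2cc(Cl)ccc12` gives 12000 nM

In a functional assay on BXPC-3 cells (Homo sapiens) for antiproliferative activity, read by sulforhodamine B assay, with a stated time of 72 h (a higher number here means a weaker inhibitor, a lower number a stronger inhibitor), compound 1 gives 12000 nM. Compound 2, with `CN(CCNCc1cn(-c2cccc(Cl)c2)nn1)CCNc1ccnc2cc(Cl)ccc12`, gives 12000 nM, and the step of no change at the digits printed from compound 1 to compound 2 (within the scatter) shows that this change left the reading where it was. Compound 2 therefore stands level with compound 1 on the numbers shown. Compound 3 `CN(CCNCc1cn(Cc2nc3cc(Cl)ccc3[nH]2)nn1)CCNc1ccnc2cc(Cl)ccc12` differs from compound 2 by (5-chloro-1H-benzimidazol-2-yl)methyl in place of 3-chlorophenyl on an aromatic nitrogen. Within the data shown here, the only measured step bearing on this position, from compound 1 to compound 2, was flat, but it swapped one halogenated phenyl for another, whereas the new group is a different kind of ring with a linking carbon. A modest shift either way cannot be ruled out, and the expected step of no change at the digits printed from compound 2 to compound 3 (within the scatter) is taken as small. Compound 3 is estimated at 12000 nM, within 4000 nM to 40000 nM.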

Compound 3, half-maximal inhibitory concentration: 44000 nM
The estimate for compound 3 lay 3.7-fold (0.56 log units) below the measured number; measured number outside the range, above it.
By their numbers in this assay, from the lowest: compounds 1 and 2 (each within the scatter of the next); then compound 3.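

The aromatic nitrogen of the five-membered ring is not indifferent to what it carries: this assay records a 3.7-fold higher number from compound 2 to compound 3 (0.56 log units; beyond the scatter), and also a 3.7-fold higher number from compound 1 to compound 3 (0.56 log units; beyond the scatter), so the (5-chloro-1H-benzimidazol-2-yl)methyl group gives a weaker inhibitor than either halogenated phenyl group. Among these compounds, the earlier step exchanged one halogenated phenyl group for another and left the reading unmoved, so only this change of group type shows that the position can respond at all. Nothing available here explains the weaker reading.

The entering group brings a linking carbon, a five-membered aromatic ring with 2 hetero atoms and a hydrogen-bond donor all at once, so the compounds shown cannot tell which of these parts matters. A plain benzyl group, which has the linking carbon but not the five-membered ring, would begin to separate them.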